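This account rests on a few compounds, and the source may have more. Where it says the series, first, only, none or still open, it means among the compounds named here.

Measured compounds in an ADME assay on L02 cells (Homo sapiens) for cytotoxicity, read by MTT assay, with a stated time of 48 h; a lower number here means a stronger inhibitor, a higher number a weaker inhibitor:

- compound 1 `O=c1ccoc2cc(OCc3cn(Cc4ccc([N+](=O)[O-])cc4)nn3)ccc12`: compound 1 gives > 300000 nM, a limit of the assay.
- compound 2 `O=c1ccoc2cc(OCc3cn(Cc4cccc(F)c4)nn3)ccc12`: compound 2 gives > 300000 nM, a limit of the assay.
- compound 3 `CC(C)(C)c1ccc(Cn2cc(COc3ccc4c(=O)ccoc4c3)nn2)cc1`: compound 3 gives > 300000 nM, a limit of the assay.

In this assay compound 2 stands only at a limit, with no number of its own. The two steps that run from compound 1, a step that the two limits leave unreadable from compound 1 to compound 2 and a step that the two limits leave unreadable from compound 1 to compound 3, cannot be read either, since both ends sit at the same limit; the whole picture is the limit of > 300000 nM in this assay, at which 3 of the 3 values shown sit. Among the compounds with values here, a change of the substituent on the benzyl group, whether to 3-fluorophenyl or to tert-butyl, therefore shows nothing readable in this assay so far.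

Compound 4 `O=c1ccoc2cc(OCc3cn(Cc4ccccc4Cl)nn3)ccc12` is the next member. Relative to compound 2 the change is 2-chlorophenyl in place of 3-fluorophenyl on a saturated chain carbon bound to an aromatic nitrogen. Both measured steps that exchange this part of the molecule left the value at the limit, so no readable step is expected for a number no higher from compound 2 to compound 4 (the limit leaves the size open). Compound 4 is accordingly expected to come out at the same limit in this assay, estimated at 300000 nM with a range from 100000 nM to 1000000 nM, and the measurement is most likely to report only a limit again.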

Compound 4, half-maximal inhibitory concentration: > 300000 nM
Compound 4 was reported as a limit (the forecaster's own chance of this, stated with the estimate: 85%); the middle value sits exactly at the limit.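

In this assay compound 4 gives > 300000 nM, a limit of the assay. Its steps from compound 1 and from compound 2 cannot be read, with both ends of each step at a limit: the limit of > 300000 nM in this assay, at which 4 of the 4 values shown sit. The compounds shown leave open how far their values lie from one another and whether any of these benzyl variations reaches a measurable value in this assay.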